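This account rests on a few compounds, and the source may have more. Where it says the series, first, only, none or still open, it means among the compounds named here.

Compound 1 `COC(=O)C1CSC(c2ccccc2O)=N1`: 14000 nM
Compound 2 `O=C(NCCCCN(CCCCNC(=O)C1CSC(c2ccccc2O)=N1)Cc1ccccc1)C1CSC(c2ccccc2O)=N1`: 3000 nM

These two numbers come from a functional assay on L1210 cells (Mus musculus) for inhibition, with a stated time of 48 h; a lower number here means a stronger inhibitor, a higher number a weaker inhibitor. Compound 2 has the lower number, 3000 nM, which makes it the stronger inhibitor of the pair, and its gap to compound 1 lies beyond the usual scatter.

Compound 3 `CC(=O)N(CCCCNC(=O)C1CSC(c2ccccc2O)=N1)CCCCNC(=O)C1CSC(c2ccccc2O)=N1` is still unmeasured and departs from compound 2 in one place, with acetyl in place of benzyl on an amine nitrogen. Among the compounds with values here, no measured pair shows this change, so its size in this assay cannot be read from the data. Compound 3 keeps the rest of compound 2, so the best guide is compound 2 at 3000 nM. A small upward move, probably not beyond the scatter, is what one would expect. The expected change is a 1.3-fold higher number from compound 2 to compound 3 (0.12 log units; within the scatter). For compound 3 the estimated value is 4000 nM, with an expected range of 1200 nM to 13000 nM.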

Compound 3, half-maximal inhibitory concentration in the L1210 assay: 21000 nM
For compound 3 the middle estimate is 5.3-fold (0.72 log units) below the measured one; the whole stated range lies below it.
By their numbers in the L1210 assay, from the lowest: compound 2; then compounds 1 and 3 (each within the scatter of the next).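

Within the data shown here, in the L1210 assay compound 2 gives 3000 nM and compound 3 gives 21000 nM here, and the group on the amine nitrogen turns out to matter, with acetyl in place of benzyl giving a 7.0-fold higher number from compound 2 to compound 3 (0.85 log units; beyond the scatter) as a step beyond the scatter, something the earlier compounds could not show with no change at this position. In a physicochemical assay for solubility, in phosphate buffer, at pH 7.1 (on this read-out higher numbers stand for higher solubility and lower numbers for lower solubility), the same change gives a 1.5-fold lower number from compound 2 to compound 3 (0.18 log units; within the scatter) and stays within the scatter, with compound 2 at 15000 nM and compound 3 at 10000 nM here, so this read-out of solubility does not separate the two compounds, while the inhibition read-out does. Nothing measured here explains the loss of inhibition. As far as these compounds go, it remains open whether the step follows the loss of the aromatic ring of benzyl or the arrival of the carbonyl of acetyl, for this one change swaps both at once. An ethyl group, a phenethyl group or a hydrogen on this nitrogen could pull those two apart.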